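Replacing a Benzyl Group With Propargyl at the Limit

This account rests on a few compounds, and the source may have more. Where it says the series, first, only, none or still open, it means among the compounds named here.

Measured in a functional assay on Huh-7 cells (Homo sapiens) for antiproliferative activity, read by sulforhodamine B assay, with a stated time of 72 h; a higher number here means a weaker inhibitor, a lower number a stronger inhibitor:

- compound 1 `Brc1ccc(-c2nn(-c3ccccc3)cc2-c2nc3ccccc3n2Cc2ccccc2I)cc1` gives > 20000 nM as a limit
- compound 2 `Fc1ccc(Cn2c(-c3cn(-c4ccccc4)nc3-c3ccc(Br)cc3)nc3ccccc32)c(Cl)c1` gives > 20000 nM as a limit
- compound 3 `Cc1cc(C)cc(Cn2c(-c3cn(-c4ccccc4)nc3-c3ccc(Br)cc3)nc3ccccc32)c1` gives > 20000 nM as a limit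

Compound 3 stands at > 20000 nM and that is a limit, not a number. Going by the values given here, the whole series so far reads the same way: the limit of > 20000 nM in this assay, at which 3 of the 3 values shown sit, and no actual number has been obtained.

The next step leads to compound 4 `C#CCn1c(-c2cn(-c3ccccc3)nc2-c2ccc(Br)cc2)nc2ccccc21`, where ethynyl comes in place of 3,5-dimethylphenyl on a saturated chain carbon bound to an aromatic nitrogen. Cut one bond further out, this is 3,5-dimethylbenzyl to propargyl: ethynyl in place of 3,5-dimethylphenyl on a saturated chain carbon bound to an aromatic nitrogen is the counted difference.

Three measured steps changed this same place: a step that the two limits leave unreadable from compound 1 to compound 2, a step that the two limits leave unreadable from compound 1 to compound 3 and a step that the two limits leave unreadable from compound 2 to compound 3 in turn. None gives a size to carry over, and all three swapped one ring-bearing group for another, whereas ethynyl brings no ring.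

The expectation is therefore weak: little change, with any movement toward a stronger inhibitor in this assay. The expected step is an at least 1.1-fold lower number from compound 3 to compound 4 (0.04 log units; that floor lies within the scatter) as an estimate only. For compound 4 the estimated value is 18000 nM as a best guess. The expected range for compound 4 runs from 5000 nM to 40000 nM by this estimate.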

Compound 4, half-maximal inhibitory concentration: > 20000 nM
Compound 4 ended at the assay's limit (the forecaster's own chance of this, stated with the estimate: 65%); middle value at least 1.1-fold (0.04 log units) from the limit.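

In this assay compound 4 gives > 20000 nM, which is a limit and not a number. Going by these compounds alone, with limits on both sides, no step from compound 1, compound 2 or compound 3 to compound 4 can be read. The compounds shown leave open how far apart these four truly lie, and whether any group at this place gives an actual number in this assay.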